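The compounds below may be only part of what the source reports. "The series", "measured", "known", "first", "only" and "open" are said of these compounds alone.

Compound 2 `CCN(CC)CCCOc1cc2ncnc(Nc3nc4ccc(C(=O)Nc5c(C)cccc5C)cc4s3)c2cc1OC` reaches only a limit in a functional assay on DLD-1 cells (Homo sapiens) for cytotoxicity, read by WST assay, with a stated time of 72 h (a higher number here means a weaker inhibitor, a lower number a stronger inhibitor), reported as > 100000 nM, so no number is known for it; this is the limit of > 100000 nM in this assay, at which 1 of the 2 values shown sits. Compound 1 `COc1cc2c(Nc3nc4ccc(C(=O)Nc5c(C)cccc5Cl)cc4s3)ncnc2cc1OCCCN1CCCCC1C`, which carries the 2-chloro-6-methylphenyl group, gives 6700 nM in this assay. Compound 3 `CCN(CC)CCCOc1cc2ncnc(Nc3nc4ccc(C(=O)Nc5c(C)cccc5Cl)cc4s3)c2cc1OC` differs from compound 2 by chloro in place of methyl on an aromatic carbon. Within the data shown here, no measured step of this kind is known here, so the direction rests on compound 1 and its 6700 nM, which shares that group with compound 3. Compound 3 is therefore expected to show an at least 2.5-fold lower number from compound 2 to compound 3 (0.39 log units; beyond the scatter), with an estimated value of 40000 nM, lying between 5000 nM and 300000 nM.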

Compound 3, half-maximal inhibitory concentration: 11700 nM
Beside the measured number, compound 3's estimate is 3.4-fold (0.53 log units) above it; the measured number falls inside the stated range.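

In this assay, among these compounds, chloro in place of methyl on the aromatic ring gives an at least 8.5-fold lower number from compound 2 to compound 3 (0.93 log units; beyond the scatter), the first measured step at this position. As far as these compounds go, its true size is unknown, as it rests on a limit for compound 2: the limit of > 100000 nM in this assay, at which 1 of the 3 values shown sits. With the 2-chloro-6-methylphenyl group kept, diethylamino in place of 2-methylpiperidin-1-yl gives a 1.7-fold higher number from compound 1 to compound 3 (0.24 log units; within the scatter), so these two amines cannot be told apart here.

From the compounds shown here alone, whether chloro is specifically required remains open, since a bromo or methoxy group at this place could behave alike. A 2,6-dichlorophenyl group would test whether the remaining methyl matters.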